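The source may hold more compounds than are shown below. What is called first, only, known or untested is meant among the compounds shown, and "the series" means these compounds.

Three nucleotide analogues have already been measured in an in vitro functional assay on 1321-N1 cells for agonist activity at P2Y purinoceptor 4 (Homo sapiens), read by scintillation proximity assay and inositol phosphate accumulation; on this read-out lower numbers stand for an effect already at smaller amounts and higher numbers for an effect only at larger amounts of compound. Compound 1 `CSc1ccn([C@@H]2O[C@H](COP(=O)(O)OP(=O)(O)OP(=O)(O)O)[C@@H](O)[C@H]2O)c(=S)n1` gives 5350 nM in this assay. Compound 2 `O=c1ccn([C@@H]2O[C@H](COP(=O)(O)OP(=O)(O)OP(=O)(O)OP(=O)(O)O)[C@@H](O)[C@H]2O)c(=S)[nH]1` gives 5520 nM, and compound 3 `O=c1[nH]c(=S)ccn1[C@@H]1O[C@H](COP(=O)(O)OP(=O)(O)OP(=O)(O)OP(=O)(O)O)[C@@H](O)[C@H]1O` gives 280 nM. Compound 2 therefore stands at the highest of the three numbers; compound 1 sits within the usual scatter of it, whereas compound 3 lies far lower: a 20-fold lower number from compound 2 to compound 3 (1.29 log units; beyond the scatter). That step comes from exchanging one ring-bearing part of the shared core for another. Compound 4 `O=c1ccn([C@@H]2O[C@H](COP(=O)(O)OP(=O)(O)OP(=O)(O)OP(=O)(O)OP(=O)(O)O)[C@@H](O)[C@H]2O)c(=S)[nH]1` is built from compound 2 by a change of a different kind, on an oxygen: a group of 4 heavy atoms (3 oxygen, 1 phosphorus; no ring) in place of a hydrogen atom, on an oxygen. For the measured compounds named here, no measured step touches this part of the molecule, so the step from compound 2 to compound 3 does not bear on it, and compound 1, which differs from compound 2 in more than one place, offers no clean comparison either. For this assay no step beyond the scatter is therefore expected, the estimated change being a 1.1-fold lower number from compound 2 to compound 4 (0.04 log units; within the scatter). Compound 4 is accordingly expected to give about 5000 nM, within 1500 nM to 16000 nM.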

Compound 4, half-maximal effective concentration: 5270 nM
For compound 4 the middle estimate is 1.1-fold (0.02 log units) below the measured one, and the stated range covers the measured number.
By their numbers in this assay, from the lowest: compound 3; then compounds 4, 1 and 2 (each within the scatter of the next).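

In this assay, for the compounds shown here, placing a group of 4 heavy atoms (3 oxygen, 1 phosphorus; no ring) in place of a hydrogen atom, on an oxygen whose other neighbours are phosphorus, gives a 1.0-fold lower number from compound 2 to compound 4 (0.02 log units; within the scatter), the first reading of a change at this place. This single addition therefore leaves the number within the usual scatter, unlike the exchange on the ring-bearing part, which gives a 20-fold lower number from compound 2 to compound 3 (1.29 log units; beyond the scatter). No evidence is available here to explain this result.

From the compounds shown here alone, whether the same addition would also leave the number within the scatter on the core of compound 3, with its much lower value, remains open. Going by these compounds, it is also open how a methyl group or an amine would read in place of that same hydrogen atom.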